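Amino in place of methoxycarbonyl: working notes

This account rests on a few compounds, and the source may have more. Where it says the series, first, only, none or still open, it means among the compounds named here.

The series shares one core and varies a single substituent on an aromatic carbon. In an ADME assay on HEp-2 cells (Homo sapiens) for cytotoxicity (on this read-out lower numbers stand for higher toxicity in this test and higher numbers for lower toxicity in this test), compound 3 (`COC(=O)c1ccc2c(c1)nc(Cn1c(=O)n(C(C)C)c3ccccc31)n2CCC(C)C`) gives 33700 nM, the second highest of three numbers. Compound 1 (`CC(=O)NCc1ccc2c(c1)nc(Cn1c(=O)n(C(C)C)c3ccccc31)n2CCC(C)C`) gives 178000 nM, and compound 2 (`C=Cc1ccc2c(c1)nc(Cn1c(=O)n(C(C)C)c3ccccc31)n2CCC(C)C`) gives 6520 nM.

The next member is compound 4 (`CC(C)CCn1c(Cn2c(=O)n(C(C)C)c3ccccc32)nc2cc(N)ccc21`), with amino in place of methoxycarbonyl on an aromatic carbon.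

All three measured steps at this position lie beyond the scatter. The largest is a 27-fold lower number from compound 1 to compound 2 (1.44 log units; beyond the scatter). The other two are modest: a 5.3-fold lower number from compound 1 to compound 3 (0.72 log units; beyond the scatter) and a 5.2-fold higher number from compound 2 to compound 3 (0.71 log units; beyond the scatter). Going by these compounds, none of them involves amino, so the direct effect of this swap is unknown. The position clearly matters, but the three compounds give no trend that can be extended to a new group. Within the data shown here, compound 1, the only measured compound with a nitrogen in this substituent, gives the highest number at 178000 nM, which hints weakly at an upward move.

The estimated step is a 1.3-fold higher number from compound 3 to compound 4 (0.13 log units; within the scatter), and it is expected to stay within the scatter, with only a slight upward lean. For compound 4 the expected value in this assay is 45000 nM, with an estimated range of 14000 nM to 140000 nM.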

Compound 4, half-maximal cytotoxic concentration: 32200 nM
The estimate for compound 4 lay 1.4-fold (0.15 log units) above the measured number; the measured number falls inside the stated range.
By their numbers in this assay, from the lowest: compound 2; then compounds 4 and 3 (each within the scatter of the next); then compound 1.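

In this assay, swapping methoxycarbonyl for amino on this aromatic carbon gives a 1.0-fold lower number from compound 3 to compound 4 (0.02 log units; within the scatter), so this change leaves the number unmoved, even though the entering group is much smaller and, unlike methoxycarbonyl, carries a hydrogen-bond donor. Amino also stands clearly apart from vinyl, with a 4.9-fold higher number from compound 2 to compound 4 (0.69 log units; beyond the scatter), so compound 2 remains the lowest of the four and compounds 3 and 4 share a middle level despite their very different substituents. A nitrogen in the substituent is not enough to reach the level of compound 1, as a 5.5-fold lower number from compound 1 to compound 4 (0.74 log units; beyond the scatter) shows, which leaves the acetamidomethyl group alone at the top of this small set and weakens the link between nitrogen and a higher number that compound 1 alone had suggested.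

No available evidence bears on why these substituents separate as they do. Going by these compounds, it remains open whether acetamide attached directly to this aromatic carbon, or aminomethyl with the same one-carbon link as compound 1 but without the acetyl group, would stay at the middle level or approach compound 1.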